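Swapping the aryl group on the shared core of compound 3

The source may report more compounds than this note shows. Statements on the series, on what has been measured and on what is new or still open speak of the compounds shown alone.

In a functional assay on KBVIN cells (Homo sapiens) for antiproliferative activity, read by sulforhodamine B assay, with a stated time of 3 days (on this read-out lower numbers stand for an effect already at smaller amounts and higher numbers for an effect only at larger amounts of compound), compound 1 `CCC1=C(O)c2c(oc(-c3ccc(CC)cc3)cc2=O)C(CC)(CC)C1=O` gives 0.07 uM, compound 2 `CCC1=C(O)c2c(oc(-c3ccc(C)cc3C)cc2=O)C(CC)(CC)C1=O` gives 8.52 uM and compound 3 `CCC1=C(O)c2c(oc(-c3ccc(OC)cc3C)cc2=O)C(CC)(CC)C1=O` gives 2.62 uM, leaving compound 3 second highest of the three numbers. Compound 4 `CCC1=C(O)c2c(oc(-c3ccc(OC)c(F)c3)cc2=O)C(CC)(CC)C1=O` carries 3-fluoro-4-methoxyphenyl in place of 4-methoxy-2-methylphenyl on an aromatic carbon. The nearest evidence is the large 37-fold higher number from compound 1 to compound 3 (1.57 log units; beyond the scatter), together with the large 120-fold higher number from compound 1 to compound 2 (2.09 log units; beyond the scatter). The modest 3.3-fold lower number from compound 2 to compound 3 (0.51 log units; beyond the scatter) bears on the methoxy group. Within the data shown here, no measured compound carries fluorine, so a large step to a lower number is expected only tentatively, stopping short of compound 1. The estimate amounts to an 8.7-fold lower number from compound 3 to compound 4 (0.94 log units; beyond the scatter). For compound 4 the estimated value is 0.3 uM, with an expected range from 0.07 uM to 1.3 uM.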

Compound 4, concentration for half-maximal effect: 0.1 uM
Estimate against measurement, compound 4: 3.0-fold (0.48 log units) above; the measured number falls inside the stated range.
By their numbers in this assay, from the lowest: compounds 1 and 4 (each within the scatter of the next); then compound 3; then compound 2.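

In this assay, the aryl position on the shared core accepts 3-fluoro-4-methoxyphenyl with a 26-fold lower number from compound 3 to compound 4 (1.42 log units; beyond the scatter) and with an 85-fold lower number from compound 2 to compound 4 (1.93 log units; beyond the scatter), while a 1.4-fold higher number from compound 1 to compound 4 (0.15 log units; within the scatter) places the two compounds within the scatter of each other. A methoxy group on this aryl ring therefore does not by itself hold the number high, as compound 3 alone might have suggested. Nothing given here accounts for the size of this change. The compounds shown do not separate the entering fluorine from the departing methyl, since both change in a single step. From the compounds shown here alone, how chlorine or a dimethylamino group would read in place of the fluorine stays open.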